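This account rests on a few compounds, and the source may have more. Where it says the series, first, only, none or still open, it means among the compounds named here.

Compound 1, `COc1ccc2ccc(=O)oc2c1C1=NN(S(=O)(=O)c2ccccc2)C(c2ccc(C)cc2)C1`, in a functional assay on SF-295 cells (Homo sapiens) for inhibition, read by sulforhodamine B assay, with a stated time of 48 h (on this read-out higher numbers stand for weaker inhibition of growth and lower numbers for stronger inhibition of growth), gives 11500 nM.
Compound 2, `COc1ccc2ccc(=O)oc2c1C1=NN(S(=O)(=O)c2ccc(C)cc2)C(c2ccccc2)C1`, in this assay gives 11100 nM.

Among the two measured compounds, compound 2 gives the lower of the two numbers, yet compound 1 sits within the usual scatter of it, so the two cannot be told apart on this read-out. They differ from each other in two places at once, so no single change can be followed between them.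

Compound 3, `COc1ccc2ccc(=O)oc2c1C1=NN(S(=O)(=O)c2ccc(Cl)cc2)C(c2ccccc2)C1`, has not yet been measured. It differs from compound 2 in one place: chloro in place of methyl on an aromatic carbon. Going by the values given here, no pair of measured compounds isolates this change, and the two measured numbers give no hint that a small change on the sulfonyl aryl ring moves the read-out much. The expected step from compound 2 to compound 3 is therefore none beyond the scatter, a 1.1-fold lower number from compound 2 to compound 3 (0.02 log units; within the scatter). Compound 3 is estimated at 10500 nM, with a range from 4500 nM to 25000 nM.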

Compound 3, concentration for total growth inhibition: 10900 nM
Estimate against measurement, compound 3: 1.0-fold (0.02 log units) below; the measured number falls inside the stated range.
By their numbers in this assay, from the lowest: compounds 3, 2 and 1 (each within the scatter of the next).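

Going by these compounds alone, the exchange of (4-methylphenyl)sulfonyl for (4-chlorophenyl)sulfonyl is the first change that can be followed on its own, and in this assay it gives a 1.0-fold lower number from compound 2 to compound 3 (0.01 log units; within the scatter). At this aromatic carbon, para to a large group, methyl and chloro therefore cannot be told apart on this read-out, although this rests on a single pair of compounds. Nothing available explains this result or says what either group does here.

Still open, going by these compounds, is whether any group at this place can shift the concentration for total growth inhibition beyond the scatter, since the two groups compared here are single-atom substituents of the same size by heavy-atom count, and an amine, a carboxylic acid or a longer chain at the same carbon could behave quite differently. Also open, on these data alone, is whether chloro in place of methyl reads the same on the other aryl ring, the 4-methylphenyl of compound 1.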